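This account rests on a few compounds, and the source may have more. Where it says the series, first, only, none or still open, it means among the compounds named here.

Compound 1 `CCCCCCCS(=O)(=O)/C=C/c1ccc(O)c(O)c1` gives 7100 nM
Compound 2 `O=S(=O)(/C=C/c1ccc(O)c(O)c1)CCCC1CCCC1` gives 6300 nM

Both values come from a functional assay, read by fluorescence and spectrophotometry, with a stated time of 1 h; a lower number here means that less compound is needed, a higher number that more compound is needed for the effect. Going by the values given here, compound 2 stands level with compound 1, the only other compound measured so far. Among the compounds with values here, the single measured step is a 1.1-fold lower number from compound 1 to compound 2 (0.05 log units; within the scatter).

Next comes compound 3 `CCCCCCCCCCS(=O)(=O)/C=C/c1ccc(O)c(O)c1`, which keeps the shared core and changes only the end of the chain: heptyl in place of cyclopentyl on a saturated chain carbon, three bonds along the chain from a sulfonyl sulfur. Heptyl replaces cyclopentyl on a saturated chain carbon, three bonds along the chain from a sulfonyl sulfur, so the ring leaves and an open chain takes its place.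

Within the data shown here, only one measured step bears on this change. It altered the same place, with cyclopentyl replacing butyl, and its size stayed within the scatter. That offers no reason to expect a large shift, but it is thin guidance, as heptyl has not yet been measured at this place.

In this assay the expected change is a 1.1-fold lower number from compound 2 to compound 3 (0.02 log units; within the scatter), so no step beyond the scatter is foreseen in either direction. For compound 3 the estimated value is 6000 nM, with an expected range from 2000 nM to 18000 nM.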

Compound 3, half-maximal effective concentration: 6800 nM
Estimate against measurement, compound 3: 1.1-fold (0.05 log units) below; the range from low to high includes it.
By their numbers in this assay, from the lowest: compounds 2, 3 and 1 (each within the scatter of the next).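

In this assay, an open chain takes the place of the ring with no step beyond the scatter: heptyl in place of cyclopentyl on a saturated chain carbon, three bonds along the chain from a sulfonyl sulfur, gives (a 1.1-fold higher number from compound 2 to compound 3 (0.03 log units; within the scatter)). The second new comparison concerns chain length, as propyl in place of hydrogen on a saturated chain carbon, seven bonds along the chain from a sulfonyl sulfur, gives (a 1.0-fold lower number from compound 1 to compound 3 (0.02 log units; within the scatter)), so this added length also stays within the scatter, and neither swap separates the compounds as the earlier single step could not show. Nothing available offers an explanation for why these readings stay so close.

As far as these compounds go, all three compounds carry only carbon and hydrogen in the varied part of the chain, so it remains open whether an amine, a carboxylic acid or a much shorter chain such as ethyl would move the number beyond the scatter. From the compounds shown here alone, the shared core also stays the same throughout, so the effect of any change there remains unknown.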